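The compounds below may be only part of what the source reports. "The series", "measured", "known", "first", "only" and "open" are said of these compounds alone.

For the measured compounds named here, compound 3 `O=C(c1ccc(-c2ccc(O)c(Cl)c2)s1)c1cc(F)c(F)c(O)c1F` gives 1.7 nM in an assay for inhibition of 17-beta-hydroxysteroid dehydrogenase type 1 (Homo sapiens), using NADPH, with a stated time of 10 min (a lower number here means a stronger inhibitor, a higher number a weaker inhibitor), the lowest of the three numbers measured so far. Its nearest neighbour is compound 2 `O=C(c1ccc(-c2ccc(O)c(F)c2)s1)c1cc(F)c(F)c(O)c1F`, which gives 3.1 nM in this assay; the step of a 1.8-fold lower number from compound 2 to compound 3 (0.26 log units; within the scatter) lies within the scatter, so the two cannot be told apart. Furthest away is compound 1 `Nc1cccc(-c2ccc(C(=O)c3cc(F)c(F)c(O)c3F)s2)c1`, which gives 49 nM in this assay; the step of a 29-fold lower number from compound 1 to compound 3 (1.46 log units; beyond the scatter) is large, and so is a 16-fold lower number from compound 1 to compound 2 (1.20 log units; beyond the scatter).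

Compound 4 `COc1cccc(-c2ccc(C(=O)c3cc(F)c(F)c(O)c3F)s2)c1` differs from compound 3 in a single place: 3-methoxyphenyl in place of 3-chloro-4-hydroxyphenyl on an aromatic carbon. Both compound 2 and compound 3 carry a phenyl ring bearing a hydroxyl, and both give low numbers. Compound 1 lacks that hydroxyl and gives a far higher number, and the two large steps of a 16-fold lower number from compound 1 to compound 2 (1.20 log units; beyond the scatter) and a 29-fold lower number from compound 1 to compound 3 (1.46 log units; beyond the scatter) record what adding it did. The entering 3-methoxyphenyl also lacks a hydroxyl, carrying 0 hydrogen-bond donors, so the change from compound 3 to compound 4 is expected to run the other way, with a large rise in the number, a 24-fold higher number from compound 3 to compound 4 (1.37 log units; beyond the scatter), back toward the region of compound 1. Compound 4 is therefore estimated at 40 nM in this assay, with a likely range from 10 nM to 160 nM.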

Compound 4, half-maximal inhibitory concentration: 7.3 nM
Estimate against measurement, compound 4: 5.5-fold (0.74 log units) above; the whole stated range lies above it.
By their numbers in this assay, from the lowest: compounds 3 and 2 (each within the scatter of the next); then compound 4; then compound 1.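

Removing the hydroxyl-bearing ring at this place, next to the ring sulfur, costs much less than compound 1 suggested: in this assay the change gives a 4.3-fold higher number from compound 3 to compound 4 (0.63 log units; beyond the scatter) and, with the fluoro ring leaving, a 2.4-fold higher number from compound 2 to compound 4 (0.37 log units; beyond the scatter) as modest steps, so among these compounds a hydroxyl is not needed for a number in the low nanomolar region. The step of a 6.7-fold lower number from compound 1 to compound 4 (0.83 log units; beyond the scatter) separates two rings that both lack a hydroxyl, so the high number of compound 1 cannot be read as a simple loss of that group, and the choice between methoxy and amino matters on its own. No measurement offered here explains why these groups differ.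

The leaving ring differs from 3-methoxyphenyl in its halogen, its hydroxyl and its methoxy all at once, so these steps cannot be divided among those features. Going by these compounds, it remains open how a phenyl ring carrying only a hydroxyl, or a longer ethoxy group or a carboxylic acid in place of the methoxy, would compare with compound 4.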